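Silyl ether aryl substituent swap in squalene monooxygenase series

A few compounds are considered here, and "the series" means these few. Any claim that something is new, unique, unknown or untested is made for them only; others in the source may bear on it.

Measured compounds:
compound 1 `CCN(CC#CC#CC(C)(C)OC)Cc1cccc(OC[Si](C)(C)c2ccccc2C)c1` — 70 nM
compound 2 `CCN(C/C=C/C#CC(C)(C)C)Cc1cccc(OC[Si](C)(C)c2ccc(Cl)cc2)c1` — 400 nM

In a functional assay on liver (Sus scrofa) for inhibition of squalene monooxygenase (Homo sapiens), using microsomes (a higher number here means a weaker inhibitor, a lower number a stronger inhibitor), compound 1 gives 70 nM, and compound 2 gives 400 nM. Compound 2 therefore stands at the highest number of the two, the weaker inhibitor, and its gap to compound 1 lies beyond the scatter. The two differ in several places at once, so the gap cannot be assigned to any one change.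

Compound 3 `CCN(C/C=C/C#CC(C)(C)C)Cc1cccc(OC[Si](C)(C)c2ccc(C)cc2)c1` keeps the core and side chain of compound 2 and differs from it in one place: methyl in place of chloro on an aromatic carbon. Within the data shown here, no pair in the set isolates this change, so there is no measured step to lean on. For a one-atom swap of this kind at this position, no shift beyond the scatter is expected; the step of a 1.1-fold lower number from compound 2 to compound 3 (0.06 log units; within the scatter) is estimated as essentially flat. Compound 3 is therefore expected to give about 350 nM in this assay, within 120 nM to 1000 nM.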

Compound 3, half-maximal inhibitory concentration: 120 nM
Compound 3: the middle estimate sits 2.9-fold (0.46 log units) above what was measured; measured number inside the range.
By their numbers in this assay, from the lowest: compounds 1 and 3 (each within the scatter of the next); then compound 2.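

In this assay, among these compounds, the change from 4-chlorophenyl to 4-methylphenyl gives the first isolated reading at this position, a 3.3-fold lower number from compound 2 to compound 3 (0.52 log units; beyond the scatter) with the core and side chain held constant. The substituent on the aromatic carbon para to a large group therefore counts in this series, and methyl carries the lower number than chloro, although this rests on a single pair. Nothing available accounts for the difference between these two groups.

On these data alone, it remains open how other groups at this carbon would read, such as hydrogen, methoxy, trifluoromethyl or a longer chain like ethyl. As far as these compounds go, it is also open whether methyl in place of chloro gives a step of similar size when paired with the side chain of compound 1.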